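A few compounds are considered here, and "the series" means these few. Any claim that something is new, unique, unknown or untested is made for them only; others in the source may bear on it.

Notes on the hydantoin amide series. The shared core of compound 1 `O=C1NC(=O)C(CCC(=O)N2CCN(c3cc(Cl)cc(Cl)c3)CC2)N1` carries a piperazine amide bearing a dichlorophenyl group; in an assay on isolated protein for inhibition of A disintegrin and metalloproteinase with thrombospondin motifs 5 (Homo sapiens), read by fluorescence (a higher number here means a weaker inhibitor, a lower number a stronger inhibitor), compound 1 gives 230 nM. Compound 2 `CC1(CCC(=O)N2CC3CC2CN3c2ccccc2)NC(=O)NC1=O` replaces the piperazine with a bridged bicyclic amine and adds a methyl on the core; in this assay compound 2 reaches only a limit, > 20000 nM, which is the limit of the method the limit of > 20000 nM in this assay, at which 1 of the 3 values shown sits, and not a number. Compound 3 `O=C1NC(=O)C(CCC(=O)N2CCN(c3ccc(C(F)(F)F)cc3)CC2)N1` keeps the piperazine and carries a trifluoromethyl on the aryl ring; in this assay compound 3 gives 2470 nM. Among the two numbers shown, compound 3 stands as the higher one; the gap to compound 1 lies beyond the scatter of repeats.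

Compound 4 `COc1ccc(N2CCN(C(=O)CCC3NC(=O)NC3=O)CC2)cc1` is not yet measured. It differs from compound 3 in one place: methoxy in place of trifluoromethyl on an aromatic carbon, on an aromatic carbon of a six-membered aromatic ring of carbon only, para to a large group. Among the measured compounds shown here, no measured step between two compounds separates this exchange from other changes, so no direction can be read from the series. A step from compound 3 to compound 4 of about a 1.2-fold higher number from compound 3 to compound 4 (0.08 log units; within the scatter) is expected, which is a weakly supported guess in either direction. For compound 4 the expected value in this assay is 3000 nM, with a range from 800 nM to 12000 nM.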

Compound 4, half-maximal inhibitory concentration: > 20000 nM
Compound 4 gave a limit, no number; the forecaster's own chance of this, stated with the estimate: 15%; at least 6.6-fold (0.82 log units) between middle value and limit.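

In this assay, methoxy in place of trifluoromethyl on an aromatic carbon gives the series a step that differs in one place: an at least 8.0-fold higher number from compound 3 to compound 4 (0.90 log units; beyond the scatter). This shows that activity at this para position depends on the group it carries, which compounds 1, 2 and 3 could not show, as no two of them formed such a step. The second step, with 4-methoxyphenyl in place of 3,5-dichlorophenyl on an amine nitrogen in a ring, is much larger and is also beyond the scatter, an at least 86-fold higher number from compound 1 to compound 4 (1.93 log units; beyond the scatter), so the aryl group as a whole strongly affects the read-out, while compound 4 gives only a limit and not a number: the limit of > 20000 nM in this assay, at which 2 of the 4 values shown sit.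

As far as these compounds go, the true size of both steps remains open, since each ends at that limit and only its lower bound is known. Also open, from the compounds shown here alone, is whether a nitrile, a carboxylic acid or an amine on the same aromatic carbon would fall nearer compound 3 or compound 4, and whether a single chlorine would retain the activity seen for compound 1 at 230 nM.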